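Adding One Chain Carbon to Compound 2

This account rests on a few compounds, and the source may have more. Where it says the series, first, only, none or still open, it means among the compounds named here.

In a physicochemical assay for acid dissociation, compound 1 (`NS(=O)(=O)c1ccc(SCCCO)c(Cl)c1`) gives 9.45 and compound 2 (`NS(=O)(=O)c1ccc(SCCO)c(F)c1`) gives 9.76 as the higher of the two numbers. The gap between them lies beyond the usual scatter.

Compound 3 (`NS(=O)(=O)c1ccc(SCCCO)c(F)c1`) departs from compound 2 in one place (hydroxymethyl in place of hydroxy on a saturated chain carbon, two bonds along the chain from a sulfur). It carries hydroxymethyl in place of hydroxy on a saturated chain carbon, two bonds along the chain from a sulfur, so that (2-hydroxyethyl)sulfanyl becomes (3-hydroxypropyl)sulfanyl.

For the measured compounds named here, no pair of measured compounds differing in one place is available, so the data give no direct measure of this change. With compound 2 at 9.76 as the reference, no step beyond the scatter is expected in this assay, in either direction. The expected change, a number 0.01 log units lower from compound 2 to compound 3 (within the scatter), is estimated to stay within the scatter. Compound 3 is therefore expected at 9.75 in this assay (estimated range 9.5 to 10).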

Compound 3, acid dissociation constant: 9.64
Compound 3: middle estimate off by 0.11 log units, on the high side, and the stated range covers the measured number.
By their numbers in this assay, from the lowest: compounds 1, 3 and 2 (each within the scatter of the next, the first and the last beyond it).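

In this assay, for the compounds shown here, the change from (2-hydroxyethyl)sulfanyl to (3-hydroxypropyl)sulfanyl now has a direct measure: a number 0.12 log units lower from compound 2 to compound 3 (within the scatter) is the first reading of hydroxymethyl in place of hydroxy at this place on the chain, and it shows that, for this pair, the added chain carbon produces no step beyond the usual scatter. Compound 3 also links to compound 1 by a single difference, fluoro in place of chloro on an aromatic carbon, and this second comparison, a number 0.19 log units higher from compound 1 to compound 3 (within the scatter), likewise stays inside the scatter with the (3-hydroxypropyl)sulfanyl chain held constant. No other measurement bears on these two steps, so the compounds offer no account of either of them.

As far as these compounds go, what a longer chain such as 4-hydroxybutyl, or an amine in place of the hydroxy, would do to this number remains open. Also open, from the compounds shown here alone, are whether the fluoro and chloro comparison would read the same with (2-hydroxyethyl)sulfanyl, and how bromo or a nitrile would read on that aromatic carbon.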